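The source may hold more compounds than are shown below. What is called first, only, known or untested is meant among the compounds shown, and "the series" means these compounds.

For the measured compounds named here, in a functional assay on Jurkat cells (Homo sapiens) for inhibition (a lower number here means a stronger inhibitor, a higher number a weaker inhibitor), compound 1 `C[C@H](NC(=O)C(=O)Nc1ccccn1)C(=O)N[C@@H](CC(=O)O)C(=O)COc1c(F)c(F)cc(F)c1F` gives 1040 nM, the highest of the three numbers measured so far. Compound 2 `C[C@H](NC(=O)C(=O)Nc1ccccc1Cl)C(=O)N[C@@H](CC(=O)O)C(=O)COc1c(F)c(F)cc(F)c1F` gives 64 nM and compound 3 `C[C@H](NC(=O)C(=O)Nc1ccccc1C(F)(F)F)C(=O)N[C@@H](CC(=O)O)C(=O)COc1c(F)c(F)cc(F)c1F` gives 61 nM; these two lie within the scatter of each other. The move to compound 4 `C[C@H](NC(=O)C(=O)Nc1ccc2c(c1)CCC2)C(=O)N[C@@H](CC(=O)O)C(=O)COc1c(F)c(F)cc(F)c1F` is 2,3-dihydro-1H-inden-5-yl in place of pyridin-2-yl on an amide-type nitrogen. Going by the values given here, two measured steps bear on it, each exchanging pyridin-2-yl for a six-membered aromatic ring of carbon only: a 16-fold lower number from compound 1 to compound 2 (1.21 log units; beyond the scatter) and a 17-fold lower number from compound 1 to compound 3 (1.23 log units; beyond the scatter). Among the compounds with values here, the 2,3-dihydro-1H-inden-5-yl also lacks the ring nitrogen, but its fused five-membered non-aromatic ring has no measured precedent, so a smaller drop than those two is expected. For compound 4 a step of a 5.8-fold lower number from compound 1 to compound 4 (0.76 log units; beyond the scatter) is expected. Compound 4 is accordingly estimated at 180 nM, with a range from 50 nM to 650 nM.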

Compound 4, half-maximal inhibitory concentration: 200 nM
The estimate for compound 4 lay 1.1-fold (0.05 log units) below the measured number; measured number inside the range.
By their numbers in this assay, from the lowest: compounds 3 and 2 (each within the scatter of the next); then compound 4; then compound 1.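

In this assay, the change on the amide-type nitrogen still lowers the number without a chloro or trifluoromethyl group, a 5.2-fold lower number from compound 1 to compound 4 (0.72 log units; beyond the scatter). The 2,3-dihydro-1H-inden-5-yl group does not match those substituted phenyl groups, however, a 3.3-fold higher number from compound 3 to compound 4 (0.52 log units; beyond the scatter) and a 3.1-fold higher number from compound 2 to compound 4 (0.49 log units; beyond the scatter), so losing the ring nitrogen does not alone set the number at this position. No measurement here explains these differences.

Still open, going by these compounds, is whether the gap comes from the fused non-aromatic ring or from the loss of the 2-chloro or 2-trifluoromethyl substituent. Unsubstituted phenyl, or phenyl carrying methoxy or an amine, would help separate these.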